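The source may hold more compounds than are shown below. What is called first, only, known or untested is meant among the compounds shown, and "the series" means these compounds.

Three compounds that share a propanoic acid on an aromatic ring, joined through an ether-linked methylene to a second ring system, have been measured for agonist activity at the free fatty acid receptor. Compound 1 `O=C(O)CCc1ccc(OCc2nc(-c3ccccc3Cl)no2)cc1` and compound 2 `O=C(O)CCc1ccc(OCc2nc(-c3ccccc3)no2)cc1` are built on one core; compound 3 `O=C(O)CCc1ccc(OCc2coc(-c3ccccc3)n2)cc1` is built on a different core, and the difference between the two cores is not broken down here.

In a functional assay on CHO cells for agonist activity at Free fatty acid receptor 1 (Homo sapiens), read by FLIPR and calcium flux, in the presence of a further agent that is not named here (a lower number here means that less compound is needed, a higher number that more compound is needed for the effect), compound 1 gives 1200 nM. In this assay compound 2 gives 1130 nM, and compound 3 gives 700 nM. The three values lie close together: compound 3 and compound 2 differ by an amount within the usual scatter, as do compound 3 and compound 1, so no order among them can be read from these numbers.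

Compound 1 and compound 2 differ in one place, by chloro in place of hydrogen on an aromatic carbon. That change gave a 1.1-fold higher number from compound 2 to compound 1 (0.03 log units; within the scatter), a step that says nothing beyond the scatter.

Compound 4 `O=C(O)CCc1ccc(OCc2coc(-c3cccc(Cl)c3)n2)cc1` has not yet been measured. It differs from compound 3 by chloro in place of hydrogen on an aromatic carbon. Among the compounds with values here, this is the same kind of change as the one from compound 2 to compound 1, but not the same change: in compound 1 the chloro sits ortho to a large group, in compound 4 it sits meta to a large group, and the two cores differ as well.

Because the earlier step of a 1.1-fold higher number from compound 2 to compound 1 (0.03 log units; within the scatter) stayed within the scatter, the expected step for compound 4 is also small, a 1.2-fold lower number from compound 3 to compound 4 (0.07 log units; within the scatter), with little confidence that the place of the chloro behaves the same way on this core. Compound 4 is therefore estimated at 600 nM in this assay, most likely between 250 nM and 1500 nM.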

Compound 4, half-maximal effective concentration: 160 nM
Compound 4: middle estimate off by 3.8-fold (0.57 log units), on the high side; the whole stated range lies above it.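

On the core of compound 3, chloro in place of hydrogen on the phenyl ring gave a 4.4-fold lower number from compound 3 to compound 4 (0.64 log units; beyond the scatter) in this assay. This shows that the change cannot simply be carried from one core to the other in this series with its size unchanged, since the two steps differ by more than the scatter allows: the same change on two cores in this assay, a 1.1-fold higher number (0.03 log units; within the scatter) from compound 2 to compound 1 and a 4.4-fold lower number (0.64 log units; beyond the scatter) from compound 3 to compound 4, 4.6-fold (0.67 log units) apart, beyond the scatter of two such steps. It does not show why they differ, since the steps differ in two things at once: the core, and the place of the chloro, which in compound 4 sits meta to a large group and in compound 1 sits elsewhere on the ring, so either difference, or both together, could lie behind the gap.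

The compounds shown leave open which of these two differences matters, a question that would need the 3-chlorophenyl group on the core of compound 1, and the chlorophenyl group of compound 1 on the core of compound 3. They also leave open whether the step from compound 3 to compound 4 is special to chloro or would also appear with another group in the same place, such as fluoro, methyl or methoxy.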